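The source may report more compounds than this note shows. Statements on the series, on what has been measured and on what is new or still open speak of the compounds shown alone.

Measured so far in a functional assay on A549 cells (Homo sapiens) for cytotoxicity, read by colorimetric assay and MTT assay, with a stated time of 3 days, tested at 1 uM; a higher number here means a weaker effect of the compound at the concentration tested, a lower number a stronger effect:

compound 1 `Cc1ccccc1-n1cc(-c2ccccc2)c(-c2ccc3c(c2)NC(=O)CO3)n1` — 94.8%
compound 2 `O=C1COc2ccc(-c3nn(-c4cc(Cl)cc(Cl)c4)cc3-c3ccccc3)cc2N1` — 93.1%
compound 3 `O=C1COc2ccc(-c3[nH]c(-c4ccccc4)nc3-c3ccccc3)cc2N1` — 95.6%

All three numbers sit close together. Compound 1 stands second highest of the three; the nearest is compound 3, and the furthest is compound 2, both within the scatter of compound 1. Among the measured compounds shown here, the one measured step that changes only a single place, a number 1.7 percentage points lower from compound 1 to compound 2 (within the scatter), swaps one aryl group for another on an aromatic nitrogen and stays within the scatter.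

The unmeasured compound 4 `O=C1COc2ccc(-c3nn(-c4ccccc4)cc3-c3ccccc3)cc2N1` differs from compound 1 by hydrogen in place of methyl on an aromatic carbon. For the measured compounds named here, no measured step touches this same position, so the only guidance is indirect: the step of a number 1.7 percentage points lower from compound 1 to compound 2 (within the scatter), which varies the aryl on the aromatic nitrogen, produced nothing beyond the scatter, and compound 3, with a different core, gives 95.6%, again close to the others. A step of a number 0.8 percentage points lower from compound 1 to compound 4 (within the scatter) is therefore expected, that is, none beyond the scatter. Compound 4 is estimated at 94%, with a range from 86% to 100%, in this assay.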

Compound 4, a percentage reported as activity, at one concentration (the size of the read-out at that concentration, not a potency): 92.2%
Beside the measured number, compound 4's estimate is 1.8 percentage points above it; low and high end bracket the measured number.
By their numbers in this assay, from the lowest: compounds 4, 2, 1 and 3 (each within the scatter of the next).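

In this assay the change from 2-methylphenyl to phenyl, hydrogen in place of methyl on an aromatic carbon ortho to a large group, gives a number 2.6 percentage points lower from compound 1 to compound 4 (within the scatter) and so leaves no effect of this methyl that can be told from the scatter. The plain phenyl is likewise not set apart from the 3,5-dichlorophenyl on the aromatic nitrogen, with a number 0.9 percentage points lower from compound 2 to compound 4 (within the scatter) as the step, so the three aryl groups on that nitrogen in compound 1, compound 2 and compound 4 all stand within the scatter of one another. No measurement is at hand that could explain these readings.

Only methyl and hydrogen have been seen at this place on the phenyl ring, and only at a single concentration. From the compounds shown here alone, whether an amine, a carboxylic acid or a longer chain there would give a step beyond the scatter stays open.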